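Chloro in place of hydroxy: compound 2 to compound 4

The source may report more compounds than this note shows. Statements on the series, on what has been measured and on what is new or still open speak of the compounds shown alone.

Compound 1 (`CC(C)=C1C(=O)N(c2ccc(Cl)cc2)N(c2ccc(Cl)cc2)C1=O`) reads 39000 nM in a functional assay on MGC-803 cells (Homo sapiens) for cytotoxicity, read by MTT assay, with a stated time of 72 h (a lower number here means a stronger inhibitor, a higher number a weaker inhibitor), and compound 2 (`O=C1C(=Cc2ccc(O)cc2)C(=O)N(c2ccc(Cl)cc2)N1c1ccc(Cl)cc1`) reads 19500 nM while compound 3 (`O=C1C(=Cc2ccc(F)cc2)C(=O)N(c2ccc(Cl)cc2)N1c1ccc(Cl)cc1`) reads 26000 nM on the same read-out. Compound 2 therefore lies within the scatter of both other compounds and holds no clear rank. Compound 4 (`O=C1C(=Cc2ccc(Cl)cc2)C(=O)N(c2ccc(Cl)cc2)N1c1ccc(Cl)cc1`) differs from compound 2 by chloro in place of hydroxy on an aromatic carbon and this is chloro in place of hydroxy on an aromatic carbon, para to a large group. Among the compounds with values here, the one measured step bearing on it is a 1.3-fold higher number from compound 2 to compound 3 (0.12 log units; within the scatter) for fluoro in place of hydroxy on an aromatic carbon. No change beyond the scatter is therefore expected in this assay here. The expected step is a 1.2-fold higher number from compound 2 to compound 4 (0.09 log units; within the scatter) in the same direction as that fluoro step. For compound 4 the estimate is 24000 nM with an expected range from 12000 nM to 48000 nM on this evidence.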

Compound 4, half-maximal inhibitory concentration: 32600 nM
For compound 4 the middle estimate is 1.4-fold (0.13 log units) below the measured one; measured number inside the range.
By their numbers in this assay, from the lowest: compounds 2, 3, 4 and 1 (each within the scatter of the next).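

In this assay chloro replaces the hydroxy of the 4-hydroxyphenyl group with a 1.7-fold higher number from compound 2 to compound 4 (0.22 log units; within the scatter) and replaces fluoro at the same place with a 1.3-fold higher number from compound 3 to compound 4 (0.10 log units; within the scatter) in the same series. Hydroxy, fluoro and chloro at this place thus stand within the scatter of one another. Going from hydroxy to chloro removes the hydrogen-bond donor and acceptor without a change beyond the scatter.

On these data alone, whether an amine, a carboxylic acid or a longer chain at this place would move the number beyond the scatter stays open. No evidence on the cause of these readings is at hand.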